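A Naphthalen-2-yl Group Replaces 4-(tert-butyl)phenyl

The compounds below may be only part of what the source reports. "The series", "measured", "known", "first", "only" and "open" are said of these compounds alone.

In a functional assay on BGC-823 cells (Homo sapiens) for inhibition, read by MTT assay, with a stated time of 72 h (on this read-out higher numbers stand for weaker inhibition and lower numbers for stronger inhibition), compound 1 `O=C1/C(=C\c2ccccc2)c2c(ncn2COCc2ccccc2)CCN1Cc1ccc(F)cc1` gives 72900 nM, and compound 2 `CC(C)(C)c1ccc(CN2CCc3ncn(COCc4ccccc4)c3/C(=C/c3ccccc3)C2=O)cc1` gives 27800 nM, the lower of the two numbers. Compound 3 `O=C1/C(=C\c2ccccc2)c2c(ncn2COCc2ccccc2)CCN1Cc1ccc2ccccc2c1` differs from compound 2 on a saturated chain carbon bound to an amide-type nitrogen in a ring: naphthalen-2-yl in place of 4-(tert-butyl)phenyl on a saturated chain carbon bound to an amide-type nitrogen in a ring. For the measured compounds named here, only one measured step bears on this change, the modest 2.6-fold lower number from compound 1 to compound 2 (0.42 log units; beyond the scatter), where tert-butyl replaces fluoro on an aromatic carbon. Going by the values given here, with only that modest step as a guide, the expected change is small, an estimated 1.2-fold higher number from compound 2 to compound 3 (0.07 log units; within the scatter), not expected to exceed the scatter. For compound 3 the estimated value is 33000 nM, with an expected range of 13000 nM to 80000 nM.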

Compound 3, half-maximal inhibitory concentration: 93300 nM
For compound 3 the middle estimate is 2.8-fold (0.45 log units) below the measured one, and the stated range ends below it.
By their numbers in this assay, from the lowest: compound 2; then compounds 1 and 3 (each within the scatter of the next).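

Swapping 4-(tert-butyl)phenyl for naphthalen-2-yl keeps the carbon count of the group yet gives a 3.4-fold higher number from compound 2 to compound 3 (0.53 log units; beyond the scatter) in this assay, so at this place on a saturated chain carbon bound to an amide-type nitrogen in a ring, the same count of heavy atoms does not guarantee the same read-out. Against the 4-fluorophenyl group, naphthalen-2-yl gives a 1.3-fold higher number from compound 1 to compound 3 (0.11 log units; within the scatter), leaving compound 2 alone apart from the other two. Nothing measured here explains this difference.

Going by these compounds, whether a pyridine ring, an amine or a carboxylic acid at this place would read like compound 2 or like compound 3 remains open.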